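A few compounds are considered here, and "the series" means these few. Any claim that something is new, unique, unknown or untested is made for them only; others in the source may bear on it.

Three compounds share a core, differing in which pyridine group sits on it and in how the core itself is built. Compound 1 has the structure `CC(=O)Nc1ccc(Nc2nccc(-c3cccnc3)n2)cc1`, and in a functional assay for inhibition, with Homo sapiens as the target (a lower number here means a stronger inhibitor, a higher number a weaker inhibitor), compound 1 gives 3600 nM. Compound 2, `CC(=O)Nc1ccc(Nc2nccc(-c3ccccn3)n2)cc1`, differs from compound 1 by one change, (pyridin-2-yl in place of pyridin-3-yl on an aromatic carbon), and in this assay compound 2 gives 1500 nM. This change made a 2.4-fold lower number from compound 1 to compound 2 (0.38 log units; beyond the scatter). Compound 3, `CC(=O)Nc1cccc(Nc2nccc(-c3cccnc3)n2)c1`, carries the same pyridin-3-yl group as compound 1 but on a different core; the difference between the two cores is not broken down here. In this assay compound 3 gives 3600 nM, level with compound 1 at the digits given and within the scatter of it.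

Compound 4, `CC(=O)Nc1cccc(Nc2nccc(-c3ccccn3)n2)c1`, has not yet been measured. It stands to compound 3 as compound 2 stands to compound 1: the change is pyridin-2-yl in place of pyridin-3-yl on an aromatic carbon, and the place of the change is described in the same words in both pairs, so it is the same change. For the measured compounds named here, only one measured example of this change exists, so the expectation rests on a single pair. Because compound 3 gives 3600 nM, level with compound 1, and because the change gave a 2.4-fold lower number from compound 1 to compound 2 (0.38 log units; beyond the scatter), a step of similar size is expected for compound 4, namely a 2.4-fold lower number from compound 3 to compound 4 (0.38 log units; beyond the scatter). Compound 4 is estimated to give 1500 nM in this assay, with a likely range from 700 nM to 3500 nM.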

Compound 4, half-maximal inhibitory concentration: 300 nM
Compound 4: middle estimate off by 5.0-fold (0.70 log units), on the high side; the whole stated range lies above it.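

In this assay, the swap of pyridin-3-yl for pyridin-2-yl gives a 12-fold lower number from compound 3 to compound 4 (1.08 log units; beyond the scatter), so the direction seen on the core of compound 1 carries over to the core of compound 3. The size of the step does not carry over, and the two steps differ by more than the usual spread of repeat measurements: the same change on two cores in this assay, a 2.4-fold lower number (0.38 log units; beyond the scatter) from compound 1 to compound 2 and a 12-fold lower number (1.08 log units; beyond the scatter) from compound 3 to compound 4, 5.0-fold (0.70 log units) apart, beyond the scatter of two such steps This shows that a step measured on one core in this series is a poor guide to the size of the same step on another, even though compound 3 and compound 1 stand level with pyridin-3-yl in place, but two pairs cannot show what in the cores sets the size of the step, nor predict its size on a third core.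

The compounds shown leave open whether pyridin-4-yl or a plain phenyl ring at the same place would match pyridin-2-yl or pyridin-3-yl on either core. They also leave open whether the larger step on the core of compound 3 would survive if the acetamide group were replaced by another group, such as a sulfonamide or a primary amine.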